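Trimethoxyphenyl-pyrimidine series: exchange of the second aryl group

The source may report more compounds than this note shows. Statements on the series, on what has been measured and on what is new or still open speak of the compounds shown alone.

Measured so far in a functional assay on HeLa cells (Homo sapiens) for antiproliferative activity, read by CCK-8 assay, with a stated time of 72 h; on this read-out lower numbers stand for stronger inhibition and higher numbers for weaker inhibition:
compound 1 `COc1ccc(-c2cncnc2-c2cc(OC)c(OC)c(OC)c2)cc1Cl`, 320 nM
compound 2 `CCOc1ccc(-c2cncnc2-c2cc(OC)c(OC)c(OC)c2)cc1`, 250 nM
compound 3 `CCOc1ccc(-c2cncnc2-c2cc(OC)c(OC)c(OC)c2)cc1F`, 470 nM

Compound 1 stands second highest of the three numbers in this assay. Its nearest neighbour is compound 2, the step being a 1.3-fold lower number from compound 1 to compound 2 (0.11 log units; within the scatter). The furthest is compound 3. Compound 1 gives 320 nM and compound 3 gives 470 nM; the two values differ by an amount described as within the scatter. The other step, a 1.9-fold higher number from compound 2 to compound 3 (0.27 log units; within the scatter), is likewise within the scatter. All three measured compounds therefore sit in one band.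

Compound 4 `COc1cc(-c2ncncc2-c2ccc(C(N)=O)cc2)cc(OC)c1OC` is not yet measured. Relative to compound 1 it carries 4-carbamoylphenyl in place of 3-chloro-4-methoxyphenyl on an aromatic carbon.

Going by the values given here, neither measured step bears directly on this change: the steps concern an ethoxy group in place of a chloro-methoxy pair and a fluoro in place of hydrogen, both within the scatter, and no compound with a carbamoyl group has been measured. The data give no basis for a direction beyond the scatter, so the expectation for compound 4 is a number near compound 1 with a broad range, the step expected being a 2.5-fold higher number from compound 1 to compound 4 (0.40 log units; beyond the scatter). Compound 4 is estimated at 800 nM, between 200 nM and 4000 nM.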

Compound 4, half-maximal inhibitory concentration: > 100000 nM
Compound 4: no number, only a limit (the forecaster's own chance of this, stated with the estimate: 10%); middle value at least 120-fold (2.09 log units) from the limit.
By their numbers in this assay, from the lowest: compounds 2, 1 and 3 (each within the scatter of the next). At a limit, above all of these: compound 4.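

In this assay compound 4 gives > 100000 nM, which is a limit of the assay and not a number: the limit of > 100000 nM in this assay, at which 1 of the 4 values shown sits. The earlier exchanges on the second aryl group all stayed within the scatter, whereas this position, on an aromatic carbon ortho to a large group, does not accept every aryl group, as the 4-carbamoylphenyl exchange gives an at least 310-fold higher number from compound 1 to compound 4 (2.49 log units; beyond the scatter), and carbamoyl in place of ethoxy gives an at least 400-fold higher number from compound 2 to compound 4 (2.60 log units; beyond the scatter). The heavy-atom count does not separate the two groups, since 3-chloro-4-methoxyphenyl and 4-carbamoylphenyl both hold 9 heavy atoms on one six-membered aromatic ring of carbon only, while the entering group carries 1 hydrogen-bond donor against 0 in the group it replaces.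

The compounds shown do not tell whether the loss belongs to the carbamoyl group as a whole or to its amide hydrogens, and a nitrile, a carboxylic acid or a methyl ester in the same place would bear on this. Nor do they tell how far from the ring a carbamoyl group would have to sit, for instance on a longer chain, for activity to return.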